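This account rests on a few compounds, and the source may have more. Where it says the series, first, only, none or still open, it means among the compounds named here.

Of the compounds shown here, three sharing one core have been measured in a toxicity assay on HeLa cells (Homo sapiens) for cytotoxicity, read by colorimetric assay, with a stated time of 72 h; a lower number here means that less compound is tolerated, a higher number that more compound is tolerated. Compound 1 `O=c1nc(N2CC[C@H](c3ccccc3)[C@@H](O)C2)sc2c([N+](=O)[O-])cc(C(F)(F)F)cc12` gives 73100 nM. Its mirror image, compound 2 `O=c1nc(N2CC[C@@H](c3ccccc3)[C@H](O)C2)sc2c([N+](=O)[O-])cc(C(F)(F)F)cc12`, gives only a limit, > 93000 nM. Compound 3 `CC(=O)c1ccc(N2CCN(c3nc(=O)c4cc(C(F)(F)F)cc([N+](=O)[O-])c4s3)CC2)cc1` likewise gives only a limit, > 105000 nM, so it stands without an exact number.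

Compound 4 `CN(C(=O)CN1CCN(c2nc(=O)c3cc(C(F)(F)F)cc([N+](=O)[O-])c3s2)CC1)c1ccccc1` has not yet been measured and differs from compound 3 in one place: (methyl(phenyl)carbamoyl)methyl in place of 4-acetylphenyl on an amine nitrogen in a ring. In words, (methyl(phenyl)carbamoyl)methyl stands in place of 4-acetylphenyl on an amine nitrogen in a ring.

Going by the values given here, the only measured step, an at least 1.2-fold higher number from compound 1 to compound 2 (0.10 log units; that floor lies within the scatter), rests on (the fact that compounds 1 and 2 differ only in the configuration as drawn). It involves no exchange of groups, so it offers no size for this change. What remains is the general level of the series. Among the compounds with values here, with compound 1 at 73100 nM as the only exact number, no step beyond the scatter is expected in this assay. Compound 4 may well return only a limit too. The estimate amounts to an at least 1.1-fold lower number from compound 3 to compound 4 (0.06 log units; that floor lies within the scatter), an expected step with no clear direction. Compound 4 is estimated at 90000 nM, with an expected range from 40000 nM to 140000 nM.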

Compound 4, half-maximal cytotoxic concentration: 70300 nM
Compound 4: the middle estimate sits 1.3-fold (0.11 log units) above what was measured; the measured number falls inside the stated range.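

In this assay, going by these compounds alone, compound 4 gives the first exact number for a group on this amine nitrogen in a ring, whereas compound 3 gave only a limit, and the only earlier step concerned configuration alone. Within the data shown here, exchanging 4-acetylphenyl for (methyl(phenyl)carbamoyl)methyl gives an at least 1.4-fold lower number from compound 3 to compound 4 (0.17 log units; that floor lies within the scatter), which is the first reading of any size for a change at this position. That reading is only a floor, and the full size of the step stays unknown, because one end of it is a limit: the limit of > 105000 nM in this assay, at which 1 of the 4 values shown sits.

The compounds shown leave open whether the true step from compound 3 to compound 4 lies beyond the scatter, since a floor within the scatter cannot settle either its size or how much the exchange matters in this assay. They also leave open how the number would respond to other groups on this amine nitrogen in a ring, such as a carboxylic acid, a simple amine or a longer chain without the phenyl ring.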